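Ring amine swap on the shared core: compound 1 to compound 3

The source may hold more compounds than are shown below. What is called first, only, known or untested is meant among the compounds shown, and "the series" means these compounds.

In an ADME assay on L6 cells (Rattus norvegicus) for cytotoxicity (a higher number here means a weaker inhibitor, a lower number a stronger inhibitor), compound 1 `CN1CCN(CCN2CCC3(N4CCCC4)CC(c4ccccc4)C2C(c2ccccc2)C3)CC1` gives 50300 nM and compound 2 `CN1CCN(CCCN2CCC3(N4CCCC4)CC(c4ccccc4)C2C(c2ccccc2)C3)CC1` gives 27500 nM. These two values lie within the scatter of each other, so compound 1 stands level with compound 2 and the pair sets no order.

Compound 3 `CN1CCN(CCN2CCC3(N4CCCCC4)CC(c4ccccc4)C2C(c2ccccc2)C3)CC1` keeps the core and the 4-methylpiperazin-1-yl chain of compound 1 and differs by piperidin-1-yl in place of pyrrolidin-1-yl on a saturated ring carbon. The swap is piperidin-1-yl in place of pyrrolidin-1-yl, on a saturated ring carbon of a six-membered non-aromatic ring of carbon only.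

Within the data shown here, only one measured step is available, a 1.8-fold lower number from compound 1 to compound 2 (0.26 log units; within the scatter). It lies on the chain rather than at this ring carbon, so it bears on the swap only indirectly, showing that the series moved little in this assay for that one change. Among the measured compounds shown here, no measured step exists for the ring amine itself. No step beyond the scatter is therefore expected in this assay, and the wide range reflects this lack of direct data.

The estimated step is a 1.3-fold lower number from compound 1 to compound 3 (0.10 log units; within the scatter). For compound 3 the expected value is 40000 nM, with an estimated range of 16000 nM to 100000 nM.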

Compound 3, half-maximal inhibitory concentration: 127000 nM
Beside the measured number, compound 3's estimate is 3.2-fold (0.50 log units) below it, outside the stated range (above it).
By their numbers in this assay, from the lowest: compounds 2 and 1 (each within the scatter of the next); then compound 3.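

In this assay, among these compounds, the ring amine on this saturated ring carbon is the first place to give a step beyond the scatter: a 2.5-fold higher number from compound 1 to compound 3 (0.40 log units; beyond the scatter). The chain change gave only a 1.8-fold lower number from compound 1 to compound 2 (0.26 log units; within the scatter), so among these compounds this ring carbon responds to a substitution while the one chain change gives no readable shift, although this rests on a single step at each place and the step at the ring carbon is modest. Nothing available accounts for the direction of the step from the five-membered to the six-membered ring amine, and no explanation can be offered for it.

As far as these compounds go, it remains open whether the number keeps moving the same way with azepan-1-yl at this ring carbon, or whether morpholin-4-yl or an open-chain amine such as dimethylamino gives a step of similar size, since a single pair cannot separate ring size from other features of the amine. From the compounds shown here alone, it is also open whether piperidin-1-yl gives a comparable step when carried on the longer chain of compound 2, which would show whether the ring amine and chain effects act independently in this assay.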